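Notes on ureido to dimethylamino in the series

The source may hold more compounds than are shown below. What is called first, only, known or untested is meant among the compounds shown, and "the series" means these compounds.

Compound 1 `NC/C=C/CN(C[C@H]1Cc2ncccc2CN1)[C@H]1CCCc2cccnc21`: 15 nm/s
Compound 2 `NC(=O)NCCCCN(C[C@H]1Cc2ncccc2CN1)[C@H]1CCCc2cccnc21`: 2 nm/s
Compound 3 `CN(C)CCCCN(C[C@H]1Cc2ncccc2CN1)[C@H]1CCCc2cccnc21`: not yet measured

In an ADME assay for permeability, using PAMPA, with a stated time of 4 h, at pH 7.4 (a higher number here means that the compound crosses the layer faster, a lower number that the compound crosses the layer more slowly), compound 2 gives 2 nm/s, the lower of the two numbers, and compound 1 gives 15 nm/s. The change to compound 3 is dimethylamino in place of ureido on a saturated chain carbon, four bonds along the chain from an amine nitrogen. Going by the values given here, only one measured step bears on this: a 7.5-fold lower number from compound 1 to compound 2 (0.88 log units; beyond the scatter), modest and beyond the scatter. Among the compounds with values here, compound 1 carries no ureido, and neither does compound 3, but no measured compound carries dimethylamino, so the guide is indirect. A modest rise of similar size is therefore expected in this assay. The expected step is a 7.0-fold higher number from compound 2 to compound 3 (0.85 log units; beyond the scatter). Compound 3 is estimated at 14 nm/s, with an expected range of 4 nm/s to 45 nm/s.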

Compound 3, apparent permeability: 240 nm/s
Compound 3: middle estimate off by 17-fold (1.23 log units), on the low side; the measured number lies above the stated range.
By their numbers in this assay, from the lowest: compound 2; then compound 1; then compound 3.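

In this assay, this position on a saturated chain carbon, four bonds along the chain from an amine nitrogen, proves far more responsive than the earlier pair suggested, with dimethylamino in place of ureido giving a 120-fold higher number from compound 2 to compound 3 (2.08 log units; beyond the scatter) as the widest step in the series. Compound 3 also stands clear of the unsaturated comparator, with 3-(dimethylamino)propyl in place of 3-aminoprop-1-en-1-yl giving a 16-fold higher number from compound 1 to compound 3 (1.20 log units; beyond the scatter), so removing ureido does not merely return the number to the level of compound 1. No supporting data bear on why these steps are so large.

Still open, going by these compounds, is how a plain amino or a methylamino group on the same saturated chain would compare with dimethylamino in this assay, which would show how much of the step depends on the two methyl groups. A longer chain carrying dimethylamino, or a carboxylic acid at this place, would test how far the trend extends.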